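A Methoxy Group Added to Compound 2

A few compounds are considered here, and "the series" means these few. Any claim that something is new, unique, unknown or untested is made for them only; others in the source may bear on it.

Two related compounds have been measured so far in an ADME assay on Vero cells (Chlorocebus sabaeus) for cytotoxicity, read by MTT assay, with a stated time of 72 h; on this read-out lower numbers stand for higher toxicity in this test and higher numbers for lower toxicity in this test. There, compound 2 `CCOC(=O)c1c(-c2ccccc2)oc2ccc(OCCCCN3C(=O)/C(=N\OC)c4cc(F)ccc43)cc12` gives 64 ug/mL and compound 1 `CCO/N=C1\C(=O)N(CCCCOc2ccc3oc(-c4ccc(OC)cc4)c(C(=O)OCC)c3c2)c2ccc(F)cc21` gives 32 ug/mL and these two numbers lie within the usual scatter of each other. Among the compounds with values here, compound 2 therefore cannot be separated from the only other measured compound.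

Compound 3 `CCOC(=O)c1c(-c2ccc(OC)cc2)oc2ccc(OCCCCN3C(=O)/C(=N\OC)c4cc(F)ccc43)cc12` arises from compound 2 through a single change. That change is methoxy in place of hydrogen on an aromatic carbon and it amounts to methoxy in place of hydrogen on an aromatic carbon, or phenyl to 4-methoxyphenyl when cut one bond further out. Within the data shown here, no measured pair shows this change alone, so the data give no size for it in this assay and no shift beyond the scatter is expected in either direction. The middle of the estimate rests on compound 1 at 32 ug/mL and compound 2 at 64 ug/mL and lies between those two numbers. The estimate places a 1.4-fold lower number from compound 2 to compound 3 (0.15 log units; within the scatter) within the scatter, as expected. For compound 3 the expected value is 45 ug/mL with 20 ug/mL to 100 ug/mL as the estimated range.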

Compound 3, half-maximal cytotoxic concentration: 32 ug/mL
Estimate against measurement, compound 3: 1.4-fold (0.15 log units) above, and the stated range covers the measured number.
By their numbers in this assay, from the lowest: compounds 1, 3 and 2 (each within the scatter of the next).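

In this assay, within the data shown here, methoxy in place of hydrogen on an aromatic carbon, para to a large group, now has a measured size for the first time: the change gives a 2.0-fold lower number from compound 2 to compound 3 (0.30 log units; within the scatter) and so stays inside the usual spread of repeated measurements. Among these compounds, the same compound also gives the first reading of a second change, hydrogen in place of methyl on a saturated chain carbon bound to an oxygen on an unsaturated carbon, which shows no change at the digits printed from compound 1 to compound 3 (within the scatter) in this test. Neither change therefore separates these compounds on this read-out, and all three remain indistinguishable in this test. Nothing available bears on the origin of these two steps.

The compounds shown leave open whether a different group at the same aromatic carbon, such as an amine, a carboxylic acid or a chlorine atom, would move the number beyond the scatter. They also leave open whether a longer chain on the saturated carbon bound to that oxygen would do so.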